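This account rests on a few compounds, and the source may have more. Where it says the series, first, only, none or still open, it means among the compounds named here.

Measured in an ADME assay on MDCK-MDR1 cells (Canis lupus familiaris) for permeability, in the apical to basolateral direction, with a stated time of 180 min; on this read-out higher numbers stand for higher permeability and lower numbers for lower permeability:
compound 1 `O=C(NCC1CCOCC1)c1ccc(C2CCCCC2)cc1`: 35.9 10^-6 cm/s
compound 2 `O=C(NCC1CCOCC1)c1ccc([C@H]2[C@@H](F)[C@@H](F)C[C@@H](F)[C@H]2F)cc1`: 20.3 10^-6 cm/s
compound 3 `O=C(NCc1cc[nH]n1)c1ccc(C2CCCCC2)cc1`: 16.7 10^-6 cm/s

Compound 2 and compound 1 differ in their cores; the difference between the two cores is not broken down here. Compound 3 carries 1H-pyrazol-3-yl in place of oxan-4-yl on a saturated chain carbon bound to an amide-type nitrogen relative to compound 1, and in this assay that change gave a 2.1-fold lower number from compound 1 to compound 3 (0.33 log units; beyond the scatter). The values of compound 2 and compound 3 lie within the usual scatter of each other, as do those of compound 2 and compound 1.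

Compound 4 `O=C(NCc1cc[nH]n1)c1ccc([C@H]2[C@@H](F)[C@@H](F)C[C@@H](F)[C@H]2F)cc1` is not yet measured. It carries the same change on the core of compound 2: 1H-pyrazol-3-yl in place of oxan-4-yl on a saturated chain carbon bound to an amide-type nitrogen. For compound 4 in this assay a step of a 2.1-fold lower number from compound 2 to compound 4 (0.32 log units; beyond the scatter) is expected, resting on the step from compound 1 to compound 3 of a 2.1-fold lower number from compound 1 to compound 3 (0.33 log units; beyond the scatter). Compound 4 is thus estimated at 9.7 10^-6 cm/s, expected between 5.5 10^-6 cm/s and 17 10^-6 cm/s.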

Compound 4, apparent permeability: 2.1 10^-6 cm/s
Beside the measured number, compound 4's estimate is 4.6-fold (0.66 log units) above it, outside the stated range (below it).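

In this assay, 1H-pyrazol-3-yl in place of oxan-4-yl on a saturated chain carbon bound to an amide-type nitrogen gives a 9.7-fold lower number from compound 2 to compound 4 (0.99 log units; beyond the scatter). The direction of the step holds on both cores, but its size does not carry over: the same change on two cores in this assay, a 2.1-fold lower number (0.33 log units; beyond the scatter) from compound 1 to compound 3 and a 9.7-fold lower number (0.99 log units; beyond the scatter) from compound 2 to compound 4, 4.5-fold (0.65 log units) apart, beyond the scatter of two such steps

With a single pair on each core, this shows that the size of the step depends on the core, but not why it does, or what size it would take on any further core. Still open, from the compounds shown here alone, is whether an amine or a carboxylic acid in place of oxan-4-yl would also give steps that differ between these two cores. A longer chain carrying 1H-pyrazol-3-yl poses the same question.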